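The source may hold more compounds than are shown below. What is called first, only, known or untested is meant among the compounds shown, and "the series" means these compounds.

Compound 3, `CC(C)Oc1cc(Oc2ccc(S(C)(=O)=O)cc2)cc(-c2ncc(C(C)C)c(=O)[nH]2)c1`, shares its core with compound 1, `CC(C)Oc1cc(Oc2ccc(S(C)(=O)=O)cc2)cc(-c2ccnc(=O)[nH]2)c1`, and compound 2, `CCc1cnc(-c2cc(Oc3ccc(S(C)(=O)=O)cc3)cc(OC(C)C)c2)[nH]c1=O`. In a physicochemical assay for lipophilicity, using the shake flask method (on this read-out higher numbers stand for higher lipophilicity and lower numbers for lower lipophilicity), compound 2 gives 3.11. For compound 1 this assay reports "not determined" (no result reported), and for compound 3 it likewise reports "not determined" (no result reported), so compound 3 stands without a number of its own, and one further compound of the set, compound 1, is in the same position. Among the measured compounds shown here, the only value that can anchor a comparison is therefore that of compound 2.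

Compound 4, `COc1cnc(-c2cc(Oc3ccc(S(C)(=O)=O)cc3)cc(OC(C)C)c2)[nH]c1=O`, has not yet been measured. The change from compound 3 to compound 4 is methoxy in place of isopropyl on an aromatic carbon. For the measured compounds named here, with no measured pair of this kind to lean on, the size of the step in this assay can only be guessed; the guess here is a drop that is larger than the usual scatter, not a gain.

For compound 4 the estimated result in this assay is 2.7, expected to fall between 2.2 and 3.2.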

Compound 4, distribution coefficient: 2.21
Compound 4: the middle estimate sits 0.49 log units above what was measured; low and high end bracket the measured number.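

In this assay, among the compounds shown here, methoxy in place of ethyl on this aromatic carbon gives the first readable step at this position: a number 0.90 log units lower from compound 2 to compound 4 (beyond the scatter). A small change of group here is therefore enough to move this read-out by more than ordinary repeat variation, while the steps involving compound 1 and compound 3, including the isopropyl to methoxy change, cannot be read without numbers for those two compounds. Nothing shown here explains the size of this step.

From the compounds shown here alone, a single readable step cannot show a trend across groups at this position, so it remains open how the read-out responds to size or to the oxygen of methoxy. Also open, going by these compounds, is where an amine, a carboxylic acid or a longer chain such as butyl would fall at this position in this assay.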